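A second methoxy on the aromatic ring: compound 3

A few compounds are considered here, and "the series" means these few. Any claim that something is new, unique, unknown or untested is made for them only; others in the source may bear on it.

The parent, compound 1 `O=C1C=CCC(/C=C/c2ccccc2)N1`, and its methoxy analogue, compound 2 `COc1ccc(/C=C/C2CC=CC(=O)N2)cc1`, both reach only limits in an ADME assay on HaCaT cells (Homo sapiens) for inhibition, read by sulforhodamine B assay, with a stated time of 48 h; a lower number here means a stronger inhibitor of growth, a higher number a weaker inhibitor of growth. In this assay compound 1 gives > 1250 uM, a limit of the assay and not a number. Compound 2 gives > 1090 uM, likewise a limit. The step that the two limits leave unreadable from compound 1 to compound 2 is therefore unreadable, as both ends sit at limits (the limit of > 1090 uM in this assay, at which 1 of the 2 values shown sits, and (the limit of > 1250 uM in this assay, at which 1 of the 2 values shown sits)). Compound 2 thus stands at a limit, with no fixed place on the scale.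

Compound 3 `COc1ccc(/C=C/C2CC=CC(=O)N2)c(OC)c1` differs from compound 2 by methoxy in place of hydrogen on an aromatic carbon. Going by the values given here, the only measured step, the same exchange of methoxy for hydrogen, could not be sized, so no direction beyond the scatter can be argued either way; the working expectation is that compound 3 also stays at the limit. Compound 3 is expected to give 1100 uM, between 450 uM and 3000 uM. The expected step that the limit leaves unreadable from compound 2 to compound 3 is thus none beyond the scatter.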

Compound 3, concentration for growth inhibition (reported as GI): > 964 uM
Compound 3 gave a limit, no number (the forecaster's own chance of this, stated with the estimate: 85%); the middle value does not contradict the limit.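

In this assay compound 3 gives > 964 uM, a limit of the assay and not a number. Going by these compounds alone, compound 2 also stands at a limit, so no step from it to compound 3 can be read. The compounds shown leave open whether the second methoxy changes growth inhibition at all.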